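Removing One Methoxy Group: From Compound 3 to Compound 4

A few compounds are considered here, and "the series" means these few. Any claim that something is new, unique, unknown or untested is made for them only; others in the source may bear on it.

The measured compounds, in a functional assay on SK-MEL-28 cells (Homo sapiens) for inhibition, read by colorimetric assay and MTT assay, with a stated time of 72 h; on this read-out higher numbers stand for weaker inhibition and lower numbers for stronger inhibition:
compound 1, `COc1ccc(-c2cc(NC(=S)NNC(=O)c3ccc(C)cc3)cs2)cc1`, gives 22000 nM;
compound 2, `Cc1ccc(C(=O)NNC(=S)Nc2csc(-c3ccccc3)c2)cc1`, gives 40000 nM;
compound 3, `COc1cc(C(=O)NNC(=S)Nc2csc(-c3ccccc3)c2)cc(OC)c1OC`, gives 55000 nM.

Compound 4, `COc1cc(OC)cc(C(=O)NNC(=S)Nc2csc(-c3ccccc3)c2)c1`, has not yet been measured. It differs from compound 3 by hydrogen in place of methoxy on an aromatic carbon. The same kind of change separates compound 1 from compound 2: hydrogen in place of methoxy on an aromatic carbon. The two places are not the same: in compound 3 the carbon that loses the methoxy is ortho to two methoxy groups and para to a large group, whereas in compound 1 it is only para to a large group. The difference between the cores of compound 1 and compound 3 is not broken down here. The earlier change gave a 1.8-fold higher number from compound 1 to compound 2 (0.26 log units; within the scatter). The number for compound 3 lies beyond the scatter from compound 1 and within it from compound 2. Compound 4 is expected to stay close to compound 3 because the earlier step was a 1.8-fold higher number from compound 1 to compound 2 (0.26 log units; within the scatter). The expected step from compound 3 to compound 4 is a 1.2-fold higher number from compound 3 to compound 4 (0.07 log units; within the scatter). The estimate for compound 4 is 65000 nM, between 28000 nM and 150000 nM.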

Compound 4, half-maximal inhibitory concentration: 37000 nM
Beside the measured number, compound 4's estimate is 1.8-fold (0.24 log units) above it; measured number inside the range.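

In this assay, replacing the methoxy group with hydrogen gave a 1.5-fold lower number from compound 3 to compound 4 (0.17 log units; within the scatter), a step that taken alone does not separate the two compounds. Set beside the earlier step, the same replacement does not carry over as one fixed shift from the core of compound 1 to the core of compound 3: the same change on two cores in this assay, a 1.8-fold higher number (0.26 log units; within the scatter) from compound 1 to compound 2 and a 1.5-fold lower number (0.17 log units; within the scatter) from compound 3 to compound 4, 2.7-fold (0.43 log units) apart, beyond the scatter of two such steps. For the compounds shown here, this does not show what sets the two steps apart, since the cores differ and so do the places: the carbon that changes in compound 3 is ortho to two methoxy groups and para to a large group, whereas the one in compound 1 is only para to a large group.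

The compounds shown leave open whether the replacement would behave in either way on further cores, or at other places on these two. They also leave open how the read-out would respond if an amine, a carboxylic acid or a longer alkoxy chain stood on the same aromatic carbon in place of the methoxy group.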